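Inverting One Ring Stereocentre in an Iminosugar Acid

The source may report more compounds than this note shows. Statements on the series, on what has been measured and on what is new or still open speak of the compounds shown alone.

Measured compounds in an assay on isolated protein for inhibition of cytosolic endo-beta-N-acetylglucosaminidase (Homo sapiens), tested at 1000 uM; on this read-out lower numbers stand for less inhibition and higher numbers for more inhibition at the one concentration tested (going by the name of the read-out): compound 1 `O=C(O)[C@H]1NC[C@H](O)[C@H](O)[C@H]1O` gives 7.6%; compound 2 `O=C(O)[C@H]1NC[C@H](O)[C@@H](O)[C@@H]1O` gives 43%; compound 3 `O=C(O)[C@@H]1NCC=C[C@H]1O` gives 14%.

Compound 2 stands highest of the three, with compound 3 nearest and compound 1 furthest. Within the data shown here, compound 4 `O=C(O)[C@H]1NC[C@@H](O)[C@@H](O)[C@@H]1O` is not yet measured. the two compounds have the same atoms and bonds and differ only in configuration as drawn: 1 of 4 stereo elements differ; a stereocentre at a saturated ring carbon is drawn S in compound 2 and R in compound 4 The only measured step that bears on this is a number 35.4 percentage points higher from compound 1 to compound 2 (beyond the scatter), which is large because of the fact that compounds 1 and 2 differ only in the configuration as drawn: a change of drawn configuration alone moved the number well beyond the scatter. Compound 4 alters fewer stereo elements than that step, in the opposite sense, so a drop beyond the scatter is expected but its size is uncertain. The estimated step from compound 2 to compound 4 is a number 23 percentage points lower from compound 2 to compound 4 (beyond the scatter). Compound 4 is expected to give about 20%, within 5% to 55%.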

Compound 4, a percentage reported as inhibition, at one concentration (the size of the read-out at that concentration, not a potency): 28%
Beside the measured number, compound 4's estimate is 8 percentage points below it, within the range that was stated.
By their numbers in this assay, from the lowest: compounds 1 and 3 (each within the scatter of the next); then compound 4; then compound 2.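

Inverting one saturated ring carbon alone gives a number 15 percentage points lower from compound 2 to compound 4 (beyond the scatter) in this assay, so a single stereocentre is enough to shift the read-out. The step with three changed stereocentres, a number 20.4 percentage points higher from compound 1 to compound 4 (beyond the scatter), is smaller than the one with two, a number 35.4 percentage points higher from compound 1 to compound 2 (beyond the scatter), so among these compounds more inversions did not mean more inhibition. The shift from compound 2 can be put down to configuration alone: the fact that compounds 2 and 4 differ only in the configuration as drawn.

The compounds shown leave open what a single inversion at each other ring carbon would do. From the compounds shown here alone, whether a methyl ester or an amide could replace the carboxylic acid also remains open.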